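Adding a Nitrile to a Second Core

The compounds below may be only part of what the source reports. "The series", "measured", "known", "first", "only" and "open" are said of these compounds alone.

Compound 1 `O=C(NCc1ccc(OCc2ccccc2)cc1)n1cccn1` and compound 2 `N#Cc1cnn(C(=O)NCc2ccc(OCc3ccccc3)cc2)c1` share one core and differ only in that compound 2 carries cyano in place of hydrogen on an aromatic carbon. In an assay on membranes from brain for binding affinity to Monoglyceride lipase (Mus musculus), read by fluorescence, with stated times of 1 h and 30 min (a higher number here means a weaker inhibitor, a lower number a stronger inhibitor), compound 1 gives 900 nM, and compound 2 gives 100 nM; the change amounts to a 9.0-fold lower number from compound 1 to compound 2 (0.95 log units; beyond the scatter). Compound 3 `O=C(N1CCCN(Cc2ccc(OCc3ccccc3)cc2)CC1)n1cccn1` places the same carbamoyl-bearing ring on a different core; the difference between the two cores is not broken down here. In this assay compound 3 gives 10000 nM, the highest number among the three measured compounds. Compound 4 `N#Cc1cnn(C(=O)N2CCCN(Cc3ccc(OCc4ccccc4)cc3)CC2)c1` repeats on the core of compound 3 the change seen from compound 1 to compound 2, namely (cyano in place of hydrogen on an aromatic carbon). The place of the change reads identically in both pairs, so it is the same change. Going by the values given here, the expected step from compound 3 to compound 4 in this assay is a 6.7-fold lower number from compound 3 to compound 4 (0.82 log units; beyond the scatter), a step kept slightly smaller than a 9.0-fold lower number from compound 1 to compound 2 (0.95 log units; beyond the scatter) since only one earlier instance supports it. Compound 4 is therefore expected to give 1500 nM, most likely between 500 nM and 5000 nM.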

Compound 4, half-maximal inhibitory concentration: 10000 nM
The estimate for compound 4 lay 6.7-fold (0.82 log units) below the measured number; measured number above the stated range.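

The 1H-pyrazol-1-yl to 4-cyano-1H-pyrazol-1-yl change, read in this assay, gives no change at the digits printed from compound 3 to compound 4 (within the scatter) on the second core, so the gain seen on the core of compound 1 did not carry over to the core of compound 3. Set side by side, the two instances of the same change differ by more than the scatter of such steps: the same change on two cores in this assay, a 9.0-fold lower number (0.95 log units; beyond the scatter) from compound 1 to compound 2 and no change at the digits printed (within the scatter) from compound 3 to compound 4, 9.0-fold (0.95 log units) apart, beyond the scatter of two such steps. Going by these compounds alone, this shows that, in this series, the size of the step from the nitrile depends on the core it sits on, but with only a single pair on each core it does not show which part of the core is responsible, or why.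

The compounds shown leave open whether another group in place of the cyano, such as a carboxylic acid or an amine, would move the number on the core of compound 3. They also leave open whether the nitrile would keep its step on a core with a longer chain.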